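The source may report more compounds than this note shows. Statements on the series, on what has been measured and on what is new or still open speak of the compounds shown alone.

Series so far, read in an ADME assay on L929 cells (Mus musculus) for cytotoxicity, read by resazurin assay, with a stated time of 72 h (on this read-out higher numbers stand for weaker inhibition and lower numbers for stronger inhibition), as follows:
Compound 1 `O=C(/C=C/c1ccc2c(c1)B(O)OC2)c1ccccc1` gives > 10 ug/mL (a limit)
Compound 2 `Cc1cccc(C(=O)/C=C/c2ccc3c(c2)B(O)OC3)c1` gives 8.56 ug/mL (a number)
Compound 3 `Nc1ccc(C(=O)/C=C/c2ccc3c(c2)B(O)OC3)cc1` gives > 10 ug/mL (a limit)

Among the compounds with values here, compound 2 holds the only number in this set. The other two values sit at one limit (the limit of > 10 ug/mL in this assay, at which 2 of the 3 values shown sit).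

Compound 4 `COc1cccc(C(=O)/C=C/c2ccc3c(c2)B(O)OC3)c1` carries methoxy in place of methyl on an aromatic carbon, meta to a large group (methoxy in place of methyl on an aromatic carbon).

The closest measured change is methyl in place of hydrogen (an at least 1.1-fold lower number from compound 1 to compound 2 (0.06 log units; that floor lies within the scatter)). The wider change from compound 2 gives only a floor as well (an at least 1.1-fold higher number from compound 2 to compound 3 (0.06 log units; that floor lies within the scatter)). Amino in place of hydrogen adds no readable size (a step that the two limits leave unreadable from compound 1 to compound 3). With these steps showing nothing beyond the scatter, no step beyond the scatter is expected in this assay for the new methoxy group. The estimated step is small (a 1.1-fold lower number from compound 2 to compound 4 (0.03 log units; within the scatter)) on this reading. For compound 4 the estimated value is 8 ug/mL with an expected range from 4 ug/mL to 14 ug/mL and a report as a limit remains possible.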

Compound 4, half-maximal inhibitory concentration: > 10 ug/mL
Compound 4 was reported as a limit; the forecaster's own chance of this, stated with the estimate: 40%; at least 1.2-fold (0.09 log units) between middle value and limit.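

In this assay, methoxy in place of methyl on this aromatic carbon, meta to a large group, brings in a hydrogen-bond acceptor, and the result is an at least 1.1-fold higher number from compound 2 to compound 4 (0.06 log units; that floor lies within the scatter), so this change shows no step beyond the scatter and its true size remains hidden behind a limit. The step from compound 1 to compound 4 cannot be read, as both of its ends are limits, and the same holds for the other unreadable steps in the series. Compound 2 remains the only compound with a number, and the series gathers at a single limit: the limit of > 10 ug/mL in this assay, at which 3 of the 4 values shown sit.

Going by these compounds, whether ethoxy, a carboxylic acid or an amine at this same position would give a number rather than a limit stays open. So do the actual values of compound 1, compound 3 and compound 4, each reported only as a limit.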